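Fluoro in place of hydrogen on 4-ethoxyphenyl

A few compounds are considered here, and "the series" means these few. Any claim that something is new, unique, unknown or untested is made for them only; others in the source may bear on it.

In a functional assay on A549 cells (Homo sapiens) for antiproliferative activity, read by MTT assay, with a stated time of 48 h (on this read-out higher numbers stand for weaker inhibition and lower numbers for stronger inhibition), compound 1 (`COc1ccc(-c2cc3c(cn2)[nH]c(=O)n3-c2cc(OC)c(OC)c(OC)c2)cc1O`) gives 630 nM and compound 2 (`COc1ccc(-c2cc3c(cn2)[nH]c(=O)n3-c2cc(OC)c(OC)c(OC)c2)cn1`) gives 1220 nM while compound 3 (`CCOc1ccc(-c2cc3c(cn2)[nH]c(=O)n3-c2cc(OC)c(OC)c(OC)c2)cc1`) gives 5300 nM as the highest number of the three. Both an 8.4-fold higher number from compound 1 to compound 3 (0.92 log units; beyond the scatter) and a 4.3-fold higher number from compound 2 to compound 3 (0.64 log units; beyond the scatter) lie beyond the scatter. Compound 4 (`CCOc1ccc(-c2cc3c(cn2)[nH]c(=O)n3-c2cc(OC)c(OC)c(OC)c2)cc1F`) has fluoro in place of hydrogen on an aromatic carbon, ortho to an ethoxy group, turning 4-ethoxyphenyl into 4-ethoxy-3-fluorophenyl (fluoro in place of hydrogen on an aromatic carbon) with the rest unchanged. Going by the values given here, no measured step adds fluoro. The measured steps exchange the whole aryl group, so a smaller step than a 4.3-fold higher number from compound 2 to compound 3 (0.64 log units; beyond the scatter) is expected, leaning towards a lower number. The estimated 1.4-fold lower number from compound 3 to compound 4 (0.14 log units; within the scatter) is expected to stay within the scatter. In this assay the expected value for compound 4 is 3800 nM with an estimated range from 1500 nM to 9000 nM for repeat measurements.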

Compound 4, half-maximal inhibitory concentration: 2540 nM
Beside the measured number, compound 4's estimate is 1.5-fold (0.17 log units) above it, and the stated range covers the measured number.
By their numbers in this assay, from the lowest: compounds 1 and 2 (each within the scatter of the next); then compound 4; then compound 3.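

a 2.1-fold lower number from compound 3 to compound 4 (0.32 log units; beyond the scatter) in this assay follows from fluoro alone, ortho to an ethoxy group, so this single hydrogen position affects the read-out beyond the scatter, whereas the earlier steps exchanged the whole aryl group. The 4-ethoxy-3-fluorophenyl group still falls short of both other aryl groups, with a 2.1-fold higher number from compound 2 to compound 4 (0.32 log units; beyond the scatter) and a 4.0-fold higher number from compound 1 to compound 4 (0.61 log units; beyond the scatter). Nothing available here explains the effect of fluoro.

Going by these compounds, whether chloro or methyl at this place would give a similar step remains open. So does the effect of a propoxy chain in place of ethoxy.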